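Fluoro for Hydrogen on the Anilino Group

The source may report more compounds than this note shows. Statements on the series, on what has been measured and on what is new or still open speak of the compounds shown alone.

Compound 1, `O=C(NC1CC1)c1ccc(-c2cnn3c(NCC4CCOCC4)nc(NC4CCCC4)nc23)cc1`, gives 690 nM in a functional assay on MDA-MB-231 cells (Homo sapiens) for antiproliferative activity; on this read-out higher numbers stand for weaker inhibition of growth and lower numbers for stronger inhibition of growth.
Compound 2, `Cc1cc(-c2cnn3c(NCC4CCOCC4)nc(Nc4ccccc4)nc23)ccc1C(=O)NC1CC1`, gives 1200 nM in this assay.

Of the compounds shown here, two have been measured so far. Compound 2 shows the higher of the two numbers in this assay, but its gap to compound 1 lies within the scatter, so the two cannot be ordered. Compound 3, `Cc1cc(-c2cnn3c(NCC4CCOCC4)nc(Nc4ccccc4F)nc23)ccc1C(=O)NC1CC1`, has not yet been measured. It differs from compound 2 in one place: fluoro in place of hydrogen on an aromatic carbon. Within the data shown here, no comparable step between measured compounds exists here, so the size of the effect is unknown. A single fluoro in place of hydrogen is a small change, and the step from compound 2 to compound 3 in this assay is expected to stay within the scatter, with no clear direction. Compound 3 is therefore estimated at 1000 nM, within a range of 350 nM to 3000 nM, a step of a 1.2-fold lower number from compound 2 to compound 3 (0.08 log units; within the scatter).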

Compound 3, concentration for 50% growth inhibition: 47 nM
The estimate for compound 3 lay 21-fold (1.33 log units) above the measured number; measured number outside the range, below it.
By their numbers in this assay, from the lowest: compound 3; then compounds 1 and 2 (each within the scatter of the next).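

The change from phenyl to 2-fluorophenyl brings a 26-fold lower number from compound 2 to compound 3 (1.41 log units; beyond the scatter) in this assay, a large step for the entry of a single fluorine atom. It shows that this place on the anilino group, an aromatic carbon ortho to a large group, responds strongly to a very small change in this assay. Compound 1 and compound 2 differ in more than one place and gave no step, so they could not show this, and nothing measured here accounts for the size of the step.

The compounds shown leave open whether the effect is particular to fluoro or would also appear with chloro, methyl or methoxy at the same place. They also leave open what fluoro would do on the other carbons of this ring, or whether a second fluoro would add to the step.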